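Swapping the Ring on the Amide Nitrogen of Compound 2

The source may report more compounds than this note shows. Statements on the series, on what has been measured and on what is new or still open speak of the compounds shown alone.

Measured compounds:
- compound 1 `CC1SC(c2cccc(C(=O)NCCCCc3ccccc3)c2)N(c2ccc(C3CC3)cc2)C1=O`: 191 nM
- compound 2 `O=C(NCCCCn1cccn1)c1cccc(C2SCC(=O)N2c2cccnc2)c1`: > 1000 nM
- compound 3 `CC(C)(C)c1conc1N1C(=O)CSC1c1cccc(C(=O)NCCCCc2ccccc2)c1`: > 1000 nM

These values come from a functional assay on HOS-TE85 cells (Homo sapiens) for inhibition, read by CCK-8 assay, with a stated time of 72 h; on this read-out higher numbers stand for weaker inhibition and lower numbers for stronger inhibition. Compound 2 gives only a limit, > 1000 nM, so its true potency is not known as a number. The same is true of compound 3, whose result of > 1000 nM is also a limit. Compound 1 is the only one of the three with a measured number, 191 nM, but it differs from compound 2 in several places, so the two values can be compared only as they stand.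

Compound 4 `O=C(NCCCCn1cccn1)c1cccc(C2SCC(=O)N2c2cccc(C3CC3)c2)c1` is built from compound 2 by one change: 3-cyclopropylphenyl in place of pyridin-3-yl on an amide-type nitrogen in a ring. The new group is larger and carries no hydrogen-bond acceptor, whereas the old one carried one. Among the measured compounds shown here, no measured pair shows this exact change, so the step is estimated from the limit of compound 2 alone; because 2 of the 3 results sit at the limit of > 1000 nM in this assay, at which 2 of the 3 values shown sit, the starting point is open-ended. The expectation is a step toward stronger inhibition, an at least 1.6-fold lower number from compound 2 to compound 4 (0.22 log units; that floor lies within the scatter), though a further limit cannot be ruled out. Compound 4 is estimated at 600 nM, with a range from 150 nM to 3000 nM.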

Compound 4, half-maximal inhibitory concentration: 299 nM
Compound 4: middle estimate off by 2.0-fold (0.30 log units), on the high side; the range from low to high includes it.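

On the amide-type nitrogen in a ring, 3-cyclopropylphenyl in place of pyridin-3-yl turns an open-ended result into a measured number: in this assay the change gives an at least 3.3-fold lower number from compound 2 to compound 4 (0.52 log units; beyond the scatter). The true size of this step remains unknown, because compound 2 gives only a limit and not a number: the limit of > 1000 nM in this assay, at which 2 of the 4 values shown sit. This is the only comparison shown between compounds that differ in one place, so it speaks for this pair alone.

The change swaps the whole ring, so the compounds shown do not separate the effect of adding the cyclopropyl group from that of replacing the ring nitrogen with carbon; a plain phenyl group at this position would help tell these apart. They also leave open whether a methyl or a methoxy group could stand in for the cyclopropyl group on the same ring.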